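Thiourea-carboxaldehyde series: aryl versus acyl substituent at the ring nitrogen

The source may report more compounds than this note shows. Statements on the series, on what has been measured and on what is new or still open speak of the compounds shown alone.

Measured so far:
compound 1, `O=CN1CCN(c2ccc(Cl)cc2)C1=S`, 26600 nM
compound 2, `O=CN1CCN(C(=O)c2ccco2)C1=S`, 2500 nM

Both compounds share the same core and were tested in a functional assay on SF-539 cells (Homo sapiens) for inhibition, read by sulforhodamine B assay, with a stated time of 48 h; a higher number here means a weaker inhibitor of growth, a lower number a stronger inhibitor of growth. Compound 1 gives 26600 nM, the highest of the two numbers. Among the measured compounds shown here, compound 2 gives 2500 nM, and the gap between these two values lies beyond the usual scatter; no step between them is counted here, so only the two numbers themselves are noted.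

Compound 3, `O=CN1CCN(c2ccc(Cl)c(Cl)c2)C1=S`, is not yet measured in this assay. It differs from compound 1 by chloro in place of hydrogen on an aromatic carbon. For the measured compounds named here, with only one added chloro on the aromatic ring and no comparable pair among the measured compounds, the expected step from compound 1 to compound 3 is small, likely within the scatter or a modest move toward a lower number: a 1.5-fold lower number from compound 1 to compound 3 (0.17 log units; within the scatter) is the estimate. Compound 3 is therefore expected to give about 18000 nM, in the range 6000 nM to 50000 nM.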

Compound 3, concentration for 50% growth inhibition: 20600 nM
Beside the measured number, compound 3's estimate is 1.1-fold (0.06 log units) below it, within the range that was stated.
By their numbers in this assay, from the lowest: compound 2; then compounds 3 and 1 (each within the scatter of the next).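

In this assay, among the compounds shown here, chloro in place of hydrogen, ortho to a chloro group and meta to a group of 8 heavy atoms, gives a 1.3-fold lower number from compound 1 to compound 3 (0.11 log units; within the scatter) and so provides the first one-place comparison. At this position on the aromatic ring, the added chloro therefore produces no change that can be told from the scatter. Nothing available bears on a reason for this result.

From the compounds shown here alone, whether an amine, a carboxylic acid or a methoxy group at the same position would give a step beyond the scatter remains open. Also open, going by these compounds, is whether a second chloro would give a similar step with the furan-2-carbonyl group of compound 2 in place of the aryl group.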